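Swapping a nitro for methoxy on a phenol Schiff base

This account rests on a few compounds, and the source may have more. Where it says the series, first, only, none or still open, it means among the compounds named here.

Measured compounds:
`Oc1ccc(F)cc1/C=N/c1ccc(OCc2ccccc2)cc1` compound 1, 15300 nM
`O=[N+]([O-])c1ccc(O)c(/C=N/c2ccc(OCc3ccccc3)cc2)c1` compound 2, 60900 nM

Among the compounds with values here, in an assay on isolated protein for inhibition of Amine oxidase [flavin-containing] B (Homo sapiens), read by fluorescence and Amplex Red, with stated times of 15 min and 20 min (a higher number here means a weaker inhibitor, a lower number a stronger inhibitor), compound 2 gives the higher of the two numbers, and the step of a 4.0-fold higher number from compound 1 to compound 2 (0.60 log units; beyond the scatter) is the only measured comparison. Compound 3 `COc1ccc(O)c(/C=N/c2ccc(OCc3ccccc3)cc2)c1` differs from compound 2 by methoxy in place of nitro on an aromatic carbon. Within the data shown here, no measured step covers methoxy, so the fluoro-to-nitro step is the only guide; it suggests that leaving nitro may move the number back toward that of compound 1. Compound 3 is therefore expected to show a 3.0-fold lower number from compound 2 to compound 3 (0.48 log units; beyond the scatter), with an estimate of 20000 nM and a range of 7000 nM to 60000 nM.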

Compound 3, half-maximal inhibitory concentration: 10700 nM
Estimate against measurement, compound 3: 1.9-fold (0.27 log units) above; the range from low to high includes it.
By their numbers in this assay, from the lowest: compounds 3 and 1 (each within the scatter of the next); then compound 2.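

In this assay, methoxy in place of nitro on this aromatic carbon, para to a hydroxy group, gives a 5.7-fold lower number from compound 2 to compound 3 (0.76 log units; beyond the scatter) and so shows that the higher number of compound 2 does not extend to every replacement at this position. Methoxy in place of fluoro gives a 1.4-fold lower number from compound 1 to compound 3 (0.16 log units; within the scatter) and so separates neither group from the other, leaving nitro alone apart among the three. No evidence here bears on the reason for this difference. The compounds shown leave open how an amine or a carboxylic acid at this position would compare, and whether any group here would give a number clearly lower than those of compound 1 and compound 3.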